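Amino for Chloro on the Longer Chain

The source may report more compounds than this note shows. Statements on the series, on what has been measured and on what is new or still open speak of the compounds shown alone.

Compound 1 `CCCCCC(CCO)n1cnc2c(Cl)nc(Cl)nc21`: 6010 nM
Compound 2 `CCCCCC(CCO)n1cnc2c(N)nc(Cl)nc21`: > 50000 nM (a limit of the assay, not a number)
Compound 3 `CCCCCCC(CCO)n1cnc2c(Cl)nc(Cl)nc21`: 12400 nM

In a functional assay on SW480 cells (Homo sapiens) for antiproliferative activity, read by MTT assay, with a stated time of 48 h (on this read-out lower numbers stand for stronger inhibition and higher numbers for weaker inhibition), only two of these compounds have true numbers, and compound 3 holds the higher one at 12400 nM. Its nearest neighbour is compound 1, as shown by a 2.1-fold higher number from compound 1 to compound 3 (0.31 log units; beyond the scatter). That modest change comes from methyl in place of hydrogen on a saturated chain carbon.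

The next compound is compound 4 `CCCCCCC(CCO)n1cnc2c(N)nc(Cl)nc21`, with amino in place of chloro on an aromatic carbon.

The same swap has been measured once, on the shorter chain, and it gave an at least 8.3-fold higher number from compound 1 to compound 2 (0.92 log units; beyond the scatter). That is a far larger change than the chain step, and it points towards weaker inhibition. Its true size is not known, since it ends at the limit of > 50000 nM in this assay, at which 1 of the 3 values shown sits.

A similarly large rise in the number is therefore expected in this assay, and the assay may well report only a limit for compound 4. The expected change is a 7.3-fold higher number from compound 3 to compound 4 (0.86 log units; beyond the scatter). The estimated value for compound 4 is 90000 nM, with an expected range of 35000 nM to 250000 nM.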

Compound 4, half-maximal inhibitory concentration: > 50000 nM
Compound 4 ended at the assay's limit; the forecaster's own chance of this, stated with the estimate: 80%; the middle value is on the limit's open side.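

In this assay, amino in place of chloro on an aromatic carbon, next to the ring nitrogen, gives an at least 4.0-fold higher number from compound 3 to compound 4 (0.60 log units; beyond the scatter), so the weakening seen on the shorter chain appears on the longer chain as well: the same change on two cores in this assay, an at least 8.3-fold higher number (0.92 log units; beyond the scatter) from compound 1 to compound 2 and an at least 4.0-fold higher number (0.60 log units; beyond the scatter) from compound 3 to compound 4; the limit leaves it open whether they differ

Both chloro compounds give true numbers and both amino compounds end at the limit of the assay, so of these two groups, only chloro at this position leaves an inhibition that can be put into a number, on either chain: the limit of > 50000 nM in this assay, at which 2 of the 4 values shown sit.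

The values of compound 2 and compound 4 are both limits, and the chain step between them cannot be read.

Going by these compounds, the true size of the amino step stays open, and with it the question of whether chain length alters that step at all. Also open, on these data alone, is how other groups at this position would behave, such as a methoxy group, a methylamino group or a plain hydrogen, and what would happen on changing the second chloro group, which is the same in all four compounds.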